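The compounds below may be only part of what the source reports. "The series", "measured", "known", "first", "only" and "open" are said of these compounds alone.

In a functional assay on MCF7 cells (Homo sapiens) for inhibition, read by MTT assay, with a stated time of 72 h (on this read-out higher numbers stand for weaker inhibition and lower numbers for stronger inhibition), compound 1 `C=CCSc1nc2nc(C)cc(Nc3cc(-c4ccccc4)[nH]n3)n2n1` gives > 50000 nM, which is a limit of the assay and not a number. Going by the values given here, compound 2 `Cc1cc(Nc2cc(-c3ccccc3)[nH]n2)n2nc(SCc3ccc(C(F)(F)F)cc3)nc2n1` gives 4820 nM, the only true number so far. Among the compounds with values here, the one measured step is an at least 10-fold lower number from compound 1 to compound 2 (1.01 log units; beyond the scatter), a large change beyond the scatter, made by putting 4-(trifluoromethyl)phenyl in place of vinyl on a saturated chain carbon bound to a sulfur.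

Compound 3 `COc1ccc(CSc2nc3nc(C)cc(Nc4cc(-c5ccccc5)[nH]n4)n3n2)cc1` keeps that aromatic ring and changes only the group on it, turning 4-(trifluoromethyl)benzyl into 4-methoxybenzyl: methoxy in place of trifluoromethyl on an aromatic carbon. Here methoxy takes the place of trifluoromethyl on an aromatic carbon, para to a large group. Within the data shown here, no measured step isolates this kind of swap. The step of an at least 10-fold lower number from compound 1 to compound 2 (1.01 log units; beyond the scatter) replaced the whole end group, and compound 3 retains most of what was added there, so a change of that size seems unlikely. The expected change is small and leans towards weaker inhibition, at about the edge of the scatter: a 1.9-fold higher number from compound 2 to compound 3 (0.27 log units; within the scatter). For compound 3 the estimated value is 9000 nM, with an expected range from 3000 nM to 30000 nM.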

Compound 3, half-maximal inhibitory concentration: 4020 nM
Beside the measured number, compound 3's estimate is 2.2-fold (0.35 log units) above it; the measured number falls inside the stated range.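

In this assay, methoxy in place of trifluoromethyl on the aromatic carbon gives a 1.2-fold lower number from compound 2 to compound 3 (0.08 log units; within the scatter), so the two groups cannot be told apart at this place, even though only methoxy counts a hydrogen-bond acceptor. The other new step is an at least 12-fold lower number from compound 1 to compound 3 (1.09 log units; beyond the scatter), which means the large step seen earlier no longer rests on a single end group: two differently substituted benzyl groups on the sulfur both go with a large step away from compound 1. Compound 1 is a limit and not a number, and both large steps start from it, so their true size stays open: the limit of > 50000 nM in this assay, at which 1 of the 3 values shown sits.

The compounds shown leave open whether the group on the ring matters at all, since a plain hydrogen, an amine or a carboxylic acid at this place might or might not stay within the scatter of these two values. They also leave open whether the aromatic ring itself is needed, a question that a longer saturated chain on the sulfur would address.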